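Adding one methyl to the isobutylcarbonyl side chain

This account rests on a few compounds, and the source may have more. Where it says the series, first, only, none or still open, it means among the compounds named here.

Measured so far in a functional assay on K562 cells (Homo sapiens) for inhibition; a lower number here means a stronger inhibitor, a higher number a weaker inhibitor
- compound 1 `CC(C)CC(=O)OC1C(C(O)CO)OC2OC(C)(C)OC21` gives 1000000 nM
- compound 2 `CC1(C)OC2OC(C(O)CO)C(OC(=O)CC(c3ccccc3)c3ccccc3)C2O1` gives 500000 nM

Compound 1 stands level with compound 2 in this assay since their two values lie within the scatter of each other, and no other measured number is available for comparison. The next compound to be tested is compound 3 `CC(C)(C)CC(=O)OC1C(C(O)CO)OC2OC(C)(C)OC21` and its change from compound 1 is methyl in place of hydrogen on a saturated chain carbon bound to three saturated chain carbons in the form of methyl in place of hydrogen on a saturated chain carbon bound to three saturated chain carbons. The same difference reads as isobutylcarbonyl to neopentylcarbonyl.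

Within the data shown here, no measured pair differs in one place only, so the series offers no direct measure of a change this small. No step beyond the scatter is expected in either direction in this assay for this change. Against compound 1, whose side chain is far smaller, compound 2 gives 500000 nM and stays within the scatter. The estimate means a 1.3-fold lower number from compound 1 to compound 3 (0.10 log units; within the scatter) as an expected step within the scatter. For compound 3 the estimated value is 800000 nM with an expected range from 300000 nM to 2000000 nM in this assay.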

Compound 3, half-maximal inhibitory concentration: 1200000 nM
Compound 3: the middle estimate sits 1.5-fold (0.18 log units) below what was measured; the range from low to high includes it.
By their numbers in this assay, from the lowest: compounds 2, 1 and 3 (each within the scatter of the next, the first and the last beyond it).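

In this assay, among these compounds, the step of a 1.2-fold higher number from compound 1 to compound 3 (0.08 log units; within the scatter) is the first direct reading of a single change. Methyl in place of hydrogen on a saturated chain carbon bound to three saturated chain carbons, which turns isobutylcarbonyl into neopentylcarbonyl, therefore moves the number no further than repeated measurements do, so at this place the extra carbon leaves the read-out unresolved from that of the parent side chain. No evidence is available on what lies behind this result.

The step is a single pair on the core of compound 1, so it cannot be extended to other side chains or other places on the shared core. Still open, going by these compounds, is whether a longer chain, an amine or a carboxylic acid in place of hydrogen at this same carbon would give a step beyond the scatter, and whether the same methyl change would read alike on the side chain of compound 2.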